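The source may hold more compounds than are shown below. What is called first, only, known or untested is meant among the compounds shown, and "the series" means these compounds.

Compound 1, `CCNc1nc(C)c(-c2nc3ccccc3s2)c(N[C@@H]2C[C@H](CO)[C@@H](O)[C@H]2O)n1`, is the lower of the two measured numbers in an ADME assay on the whole organism (plasma) for pharmacokinetics, with Rattus norvegicus as the target, with a stated time of 6 h, at a dose of 10 mg/kg by the oral route; on this read-out higher numbers stand for higher exposure at the dose given and lower numbers for lower exposure: compound 1 gives 2580 ng.h/mL, while compound 2, `Cc1nc(NC(C)C)nc(N[C@@H]2C[C@H](CO)[C@@H](O)[C@H]2O)c1-c1nc2ccccc2s1`, gives 8420 ng.h/mL. Going by the values given here, the one measured step is a 3.3-fold higher number from compound 1 to compound 2 (0.51 log units; beyond the scatter), a change of methyl in place of hydrogen on a saturated chain carbon bound to a nitrogen on an aromatic ring and a saturated chain carbon.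

Compound 3, `Cc1nc(NCc2cccs2)nc(N[C@@H]2C[C@H](CO)[C@@H](O)[C@H]2O)c1-c1nc2ccccc2s1`, differs from compound 1 by thiophen-2-yl in place of methyl on a saturated chain carbon bound to a nitrogen on an aromatic ring, so the ethylamino of compound 1 becomes ((thiophen-2-yl)methyl)amino. Among the compounds with values here, no measured step changes this position in that way; the step from compound 1 to compound 2 shows only that this position is sensitive in this assay, and it does not say which way a thiophen-2-yl would move the number. The estimate for compound 3 therefore stays near compound 1 with a wide range: it is expected to give 2000 ng.h/mL, between 600 ng.h/mL and 6500 ng.h/mL, a step of a 1.3-fold lower number from compound 1 to compound 3 (0.11 log units; within the scatter), which may well lie within the scatter.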

Compound 3, area under the concentration-time curve: 242 ng.h/mL
Beside the measured number, compound 3's estimate is 8.3-fold (0.92 log units) above it; the whole stated range lies above it.
By their numbers in this assay, from the lowest: compound 3; then compound 1; then compound 2.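

The thiophen-2-yl change shows that this position can push the number down as well as up in this assay: putting thiophen-2-yl in place of methyl gives an 11-fold lower number from compound 1 to compound 3 (1.03 log units; beyond the scatter), and (thiophen-2-yl)methyl in place of isopropyl on the nitrogen gives a 35-fold lower number from compound 2 to compound 3 (1.54 log units; beyond the scatter). Going by these compounds alone, both steps are large, whereas the only earlier step, a 3.3-fold higher number from compound 1 to compound 2 (0.51 log units; beyond the scatter), was modest and upward, so the number does not move in one direction as heavy atoms are added to this chain: one added methyl raises it, while the five heavy atoms of thiophen-2-yl in place of methyl lower it. Nothing available explains why exposure falls so steeply with this group.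

The three compounds leave open whether the fall belongs to the thiophene ring in particular or to any ring at this place, which a benzyl or a cyclopropylmethyl group on the nitrogen would help to separate. They also leave open whether the rise seen with isopropyl continues with a further branched chain such as tert-butyl, or with a ring such as cyclobutyl placed directly on the nitrogen.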